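This account rests on a few compounds, and the source may have more. Where it says the series, first, only, none or still open, it means among the compounds named here.

In a functional assay on NCI-H1975 cells (Homo sapiens) for antiproliferative activity, read by MTT assay, with a stated time of 72 h (a higher number here means a weaker inhibitor, a lower number a stronger inhibitor), compound 1 `COc1cc(F)c(NC(=O)c2ccnc(Cl)c2)cc1Nc1nccc(-c2cn(C)c3ccccc23)n1` gives 4330 nM. Among the three compounds measured so far this is the second highest number. Compound 2 `COc1cc(F)c(NC(=O)c2ccncc2OC)cc1Nc1nccc(-c2cn(C)c3ccccc23)n1` gives 4120 nM in this assay, and the step of a 1.1-fold lower number from compound 1 to compound 2 (0.02 log units; within the scatter) lies within the usual scatter. Compound 3 `COc1cc(F)c(NC(=O)c2cnccn2)cc1Nc1nccc(-c2cn(C)c3ccccc23)n1` gives 24800 nM in this assay; the step of a 5.7-fold higher number from compound 1 to compound 3 (0.76 log units; beyond the scatter) and the step of a 6.0-fold higher number from compound 2 to compound 3 (0.78 log units; beyond the scatter) both go beyond the scatter. All three measured steps exchange the aromatic group that sits on the carbonyl carbon of the amide, and nothing else.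

Compound 4 `COc1cc(N(C)C)c(NC(=O)c2ccnc(Cl)c2)cc1Nc1nccc(-c2cn(C)c3ccccc23)n1` differs from compound 1 in a different place: dimethylamino in place of fluoro on an aromatic carbon. Among the measured compounds shown here, no measured step touches this position; every comparison available alters only the group on the carbonyl carbon, so the data give no direct guide to the size or direction of the change from fluoro to dimethylamino. The expectation therefore rests on the shared remainder of the structure, with a wide range to cover the uncertainty. For compound 4 the expected step is a 1.1-fold lower number from compound 1 to compound 4 (0.03 log units; within the scatter). Compound 4 is expected to give about 4000 nM in this assay, with the estimate ranging from 1000 nM to 16000 nM.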

Compound 4, half-maximal inhibitory concentration: 9200 nM
Estimate against measurement, compound 4: 2.3-fold (0.36 log units) below, and the stated range covers the measured number.
By their numbers in this assay, from the lowest: compounds 2 and 1 (each within the scatter of the next); then compound 4; then compound 3.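

In this assay, among the compounds shown here, the aromatic carbon ortho to the ((2-chloropyridin-4-yl)carbonyl)amino group now gives its first reading, since the earlier steps changed only the group on the carbonyl carbon. Replacing fluoro, a single heavy atom, with dimethylamino, which has three heavy atoms and one hydrogen-bond acceptor, gives a 2.1-fold higher number from compound 1 to compound 4 (0.33 log units; beyond the scatter), so this position does affect the read-out, though the change is modest and in the weaker direction. No measurement here accounts for this shift, so it stands as an observation without an established cause.

A single replacement cannot show whether the shift follows the size of the group or something particular to dimethylamino; a plain amine, a methoxy group or a longer chain such as 2-(dimethylamino)ethylamino at this position would help separate those possibilities. Going by these compounds, it also remains open whether dimethylamino would shift the numbers in the same direction and to a similar extent when paired with the 3-methoxypyridin-4-yl or pyrazin-2-yl group on the carbonyl carbon.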